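This account rests on a few compounds, and the source may have more. Where it says the series, first, only, none or still open, it means among the compounds named here.

Measured compounds:
Compound 1, `CCCCCCCC/C=C\CCCCCCC(=O)c1ccccn1`; in an assay on isolated protein for inhibition of Fatty-acid amide hydrolase 1 (Homo sapiens) (a higher number here means a weaker inhibitor, a lower number a stronger inhibitor), compound 1 gives > 100000 nM, a limit of the assay.
Compound 2, `CCCCCCCC/C=C\CCCCCCC(=O)c1nnn(C)n1`; in this assay compound 2 gives 65 nM.
Compound 3, `CCCCCCCC/C=C\CCCCCCC(=O)c1nccn1C`; in this assay compound 3 gives > 100000 nM, a limit of the assay.

Compound 3 thus stands at the limit of > 100000 nM in this assay, at which 2 of the 3 values shown sit, and no number is known for it. Compound 4 `CCCCCCCC/C=C\CCCCCCCC(OC)OC` differs from compound 3 by 2,2-dimethoxyethyl in place of (1-methyl-1H-imidazol-2-yl)carbonyl on a saturated chain carbon, six bonds along the chain from a double-bonded chain carbon. Going by the values given here, this change removes the carbonyl together with its attached group, so none of the measured steps touches it directly: an at least 1500-fold lower number from compound 1 to compound 2 (3.18 log units; beyond the scatter) and an at least 1500-fold higher number from compound 2 to compound 3 (3.18 log units; beyond the scatter) exchange one group for another on the carbonyl, while a step that the two limits leave unreadable from compound 1 to compound 3. With compound 3 already at a limit, the step of a number no higher from compound 3 to compound 4 (the limit leaves the size open) is expected to leave compound 4 at a limit as well. Compound 4 is therefore estimated at 100000 nM, within 30000 nM to 300000 nM.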

Compound 4, inhibition constant: > 300000 nM
Compound 4 ended at the assay's limit; the forecaster's own chance of this, stated with the estimate: 80%; at least 3.0-fold (0.47 log units) between middle value and limit.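

In this assay compound 4, which has 2,2-dimethoxyethyl at this place and no carbonyl, gives > 300000 nM, a limit of the assay. Going by these compounds alone, the one readable step is an at least 4600-fold higher number from compound 2 to compound 4 (3.66 log units; beyond the scatter), so this acetal end joins the pyridin-2-yl and 1-methyl-1H-imidazol-2-yl ketones at a limit, and among the four compounds only the 2-methyl-2H-tetrazol-5-yl ketone gives a number. The steps from compound 1 and from compound 3 to compound 4 cannot be read, as both ends are limits.

As far as these compounds go, whether a carboxylic acid or an amide at this place would give a number stays open. So does how far compound 1, compound 3 and compound 4 lie from one another.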